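Methylsulfonyl for oxan-4-yl on a fused benzimidazole-bearing core

The compounds below may be only part of what the source reports. "The series", "measured", "known", "first", "only" and "open" are said of these compounds alone.

Measured compounds:
compound 1, `C[C@@H]1CN(c2sc(C(F)(F)F)nc2-c2nc3ccccc3[nH]2)CCN1C(=O)Cn1cccn1`: 191 nM
compound 2, `Cc1nc(C)n(CC(=O)N2CCN(c3sc(C(F)(F)F)nc3-c3nc4ccc(C5CCOCC5)cc4[nH]3)C[C@H]2C)n1`: 123 nM
compound 3, `Cc1nc(C)n(CC(=O)N2CCN(c3sc(C(F)(F)F)nc3-c3nc4c(C(F)(F)F)cccc4[nH]3)C[C@H]2C)n1`: 747 nM

In a functional assay on Venous blood for antagonist activity at C-X-C chemokine receptor type 3 (Homo sapiens), read by flow cytometry, with a stated time of 30 min, in the presence of a further agent that is not named here (a lower number here means a stronger inhibitor, a higher number a weaker inhibitor), compound 2 gives 123 nM, the lowest of the three numbers. Compound 1, at 191 nM, sits within the usual scatter of compound 2, so no order between the two can be read from these figures. Compound 3, at 747 nM, lies beyond the scatter and is the weakest of the three.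

Compound 4, `Cc1nc(C)n(CC(=O)N2CCN(c3sc(C(F)(F)F)nc3-c3nc4ccc(S(C)(=O)=O)cc4[nH]3)C[C@H]2C)n1`, is the untested analogue of compound 2. The two share the same core and the same amide-bearing side chain; the change is methylsulfonyl in place of oxan-4-yl on an aromatic carbon. Going by the values given here, no pair of measured compounds differs in a single place, so the three values give no direct precedent for a swap of this kind at this position.

Because compound 2 gives 123 nM and compound 1, lacking any group at that position, gives 191 nM, the group at this carbon appears to matter little between those two. Compound 4 is therefore expected to land near compound 2, with a step of a 1.6-fold higher number from compound 2 to compound 4 (0.21 log units; within the scatter) that is estimated to be small and possibly within the scatter. The estimated value for compound 4 in this assay is 200 nM, with a range from 70 nM to 600 nM.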

Compound 4, half-maximal inhibitory concentration: 959 nM
Compound 4: middle estimate off by 4.8-fold (0.68 log units), on the low side; the whole stated range lies below it.
By their numbers in this assay, from the lowest: compounds 2 and 1 (each within the scatter of the next); then compounds 3 and 4 (each within the scatter of the next).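

In this assay the replacement of oxan-4-yl by methylsulfonyl on this aromatic carbon is not a neutral exchange: it gives a 7.8-fold higher number from compound 2 to compound 4 (0.89 log units; beyond the scatter) and shows that the group held at this carbon can count for a clear part of the activity. This is the only pair among the compounds shown that differs in a single place, so the shared core and the amide-bearing side chain are held constant and the loss of activity goes with this one swap. No measurement here accounts for that loss.

The swap removes a ring and brings in a sulfonyl group in one move, so the pair cannot show which of the two changes carries the step. A plain methyl, a methoxy group or a morpholine ring on the same carbon would help separate these two changes, and a methylsulfonyl group on another carbon of the same aromatic ring would show whether the step belongs to this place or to the group wherever it stands.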